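This account rests on a few compounds, and the source may have more. Where it says the series, first, only, none or still open, it means among the compounds named here.

Compound 3 `CCOC(=O)c1cc(-c2cccc(OCc3ccccc3F)c2)on1` has no result in an ADME assay on Vero cells (Chlorocebus sabaeus) for cytotoxicity, with a stated time of 72 h; a higher number here means a weaker inhibitor, a lower number a stronger inhibitor; for compound 3 the entry reads "not determined" (no result reported). Compound 1 `CCOC(=O)c1cc(-c2cccc(OCc3cccc(F)c3)c2)on1` reaches only the limit of this assay, > 128000 nM. Compound 2 `CCOC(=O)c1cc(-c2cccc(OCc3cccc(OC)c3)c2)on1` likewise stops at the limit, > 128000 nM. The step that the two limits leave unreadable from compound 1 to compound 2 is therefore unreadable, and the limit of > 128000 nM in this assay, at which 2 of the 3 values shown sit, is all the series offers on cytotoxicity. Compound 4 `CCOC(=O)c1cc(-c2cccc(OCc3cccc(C(F)(F)F)c3F)c2)on1` differs from compound 3 by trifluoromethyl in place of hydrogen on an aromatic carbon. Among the compounds with values here, no measured step bears on this change, and compound 3 itself carries no number, so neither direction nor size can be read from the series; the two values that do exist both sit at the limit. Compound 4 is expected to give 128000 nM, with a range of 64000 nM to 300000 nM, most likely reported again only as a limit.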

Compound 4, half-maximal inhibitory concentration: > 128000 nM
Compound 4 gave a limit, no number (the forecaster's own chance of this, stated with the estimate: 85%); the middle value sits exactly at the limit.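

No step can be read from compound 3 to compound 4, as compound 3 carries no result. In this assay, compound 4 gives > 128000 nM, a limit and not a number. Going by these compounds, whether trifluoromethyl in place of hydrogen alters cytotoxicity remains open.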